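The source may hold more compounds than are shown below. What is called first, only, known or untested is meant among the compounds shown, and "the series" means these compounds.

Measured compounds, all in an assay on isolated protein for inhibition of protein kinase C theta type (Homo sapiens), read by TR-FRET, with a stated time of 2 h; on this read-out higher numbers stand for weaker inhibition and lower numbers for stronger inhibition:
compound 1 `N#Cc1cnc(NCc2cnccc2C(F)(F)F)cc1NC[C@H]1C[C@@H](O)C1`: 300 nM
compound 2 `N#Cc1cnc(NCc2cnccc2C(F)(F)F)cc1NCC1CCOCC1`: 400 nM
compound 3 `N#Cc1cnc(NCc2cnccc2C(F)(F)F)cc1NCCC1CCOCC1`: 1200 nM

Compound 3 gives the highest number of the three in this assay; its nearest neighbour is compound 2, a step of a 3.0-fold higher number from compound 2 to compound 3 (0.48 log units; beyond the scatter), and compound 1 lies furthest, a step of a 4.0-fold higher number from compound 1 to compound 3 (0.60 log units; beyond the scatter). Compound 4 `CC1(C)[C@H](Nc2cc(NCc3cnccc3C(F)(F)F)ncc2C#N)C[C@H]1C(N)=O` differs from compound 3 in 3-carbamoyl-2,2-dimethylcyclobutyl in place of 2-(oxan-4-yl)ethyl on a nitrogen on an aromatic ring. The two measured steps that end at compound 3 both bear on this change: each sets a shorter link on the same nitrogen against the 2-(oxan-4-yl)ethyl chain of compound 3, and each gave a modest move to a higher number. Compound 4 shortens that link further, to a ring bound directly to the nitrogen, carrying a hydrogen-bond donor as compound 1 does. Compound 4 is therefore expected to give a lower number in this assay, a step of about a 4.0-fold lower number from compound 3 to compound 4 (0.60 log units; beyond the scatter), estimated at 300 nM with a range of 80 nM to 1100 nM.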

Compound 4, half-maximal inhibitory concentration: 140 nM
Compound 4: middle estimate off by 2.1-fold (0.33 log units), on the high side; measured number inside the range.
By their numbers in this assay, from the lowest: compound 4; then compounds 1 and 2 (each within the scatter of the next); then compound 3.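

In this assay a ring bound directly to the nitrogen on an aromatic ring is accepted: 3-carbamoyl-2,2-dimethylcyclobutyl gives an 8.6-fold lower number from compound 3 to compound 4 (0.93 log units; beyond the scatter) against 2-(oxan-4-yl)ethyl, a 2.9-fold lower number from compound 2 to compound 4 (0.46 log units; beyond the scatter) against (oxan-4-yl)methyl and a 2.1-fold lower number from compound 1 to compound 4 (0.33 log units; beyond the scatter) against (3-hydroxycyclobutyl)methyl. Among the compounds shown here, all three steps lie beyond the scatter, so compound 4 is the strongest of the four, and the earlier compounds all kept a chain link. No evidence at hand accounts for this gain. Going by these compounds, the link, ring and carbamoyl change together, so which carries the step stays open. Also open, on these data alone, is whether plain cyclobutyl, or a carboxylic acid replacing the carbamoyl, would hold the number.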